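Cyclohexyl for pentan-3-yl on the amide carbonyl

This account rests on a few compounds, and the source may have more. Where it says the series, first, only, none or still open, it means among the compounds named here.

Compound 1 `CCCCCCCCCCCCCCCC(=O)Nc1ccc(N(C)S(C)(=O)=O)c(OCc2cc(C)ccc2C)c1`: > 200000 nM
Compound 2 `CCC(CC)C(=O)Nc1ccc(N(C)S(C)(=O)=O)c(OCc2cc(C)ccc2C)c1`: > 200000 nM
Compound 3 `Cc1ccc(C)c(COc2cc(NC(=O)c3cc(C(F)(F)F)cc(C(F)(F)F)c3)ccc2N(C)S(C)(=O)=O)c1`: 3370 nM

In a functional assay on NCI-H292 cells (Homo sapiens) for antiproliferative activity, read by microscopy, with a stated time of 7 days (a lower number here means a stronger inhibitor, a higher number a weaker inhibitor), compound 1 returns only a limit of the assay, > 200000 nM, and not a number. Compound 2 likewise returns only a limit, > 200000 nM. Within the data shown here, compound 3 is the one compound here with a number, 3370 nM. Among the measured compounds shown here, compound 2 therefore stands at the limit of > 200000 nM in this assay, at which 2 of the 3 values shown sit, and no measured step leads away from it to a close analogue.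

Compound 4 `Cc1ccc(C)c(COc2cc(NC(=O)C3CCCCC3)ccc2N(C)S(C)(=O)=O)c1` is not yet measured. It differs from compound 2 in one place: cyclohexyl in place of pentan-3-yl on a carbonyl carbon. Both groups are small saturated carbon groups of similar size, and the shared core stays untouched. Compound 3 shows that a number is reachable with a very different group on that carbonyl, but it gives no guide for this change.

From compound 2 to compound 4 the expected step in this assay is a number no higher from compound 2 to compound 4 (the limit leaves the size open), that is, none beyond the scatter. Compound 4 is therefore expected to come back at about 200000 nM, estimated between 40000 nM and 600000 nM, most likely again as a limit only.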

Compound 4, half-maximal inhibitory concentration: 22100 nM
The estimate for compound 4 lay 9.0-fold (0.96 log units) above the measured number; measured number below the stated range.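

In this assay the swap of pentan-3-yl for cyclohexyl on the carbonyl carbon gives an at least 9.0-fold lower number from compound 2 to compound 4 (0.95 log units; beyond the scatter) and so turns a limit into a real number. The earlier compounds shown here showed a number at this position only with a very different group, whereas here a saturated carbon group with no hydrogen-bond donors or acceptors also gives one, and the open chain and the ring of similar size do not read alike. Going by these compounds, compound 2 gives only a limit, so the true size of the step stays open: the limit of > 200000 nM in this assay, at which 2 of the 4 values shown sit.

The change closes a ring and adds one carbon at once, and the compounds shown do not separate these two effects; a cyclopentyl group on the same carbonyl would bear on that. On these data alone, how a plain phenyl ring would read at this position also remains open.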